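Swapping an isopropyl for a methylsulfanyl-phenyl arm

The source may hold more compounds than are shown below. What is called first, only, known or untested is meant among the compounds shown, and "the series" means these compounds.

Of the compounds shown here, three sharing one core have been measured in a functional assay on MDA-MB-231 cells (Homo sapiens) for antiproliferative activity, read by MTT assay, with a stated time of 72 h; a lower number here means a stronger inhibitor, a higher number a weaker inhibitor. Compound 1 `CC(C)c1cccc(NC(=O)CCc2cccc3c2B(O)OC3)c1` gives 1600 nM in this assay, which places it second highest among the three numbers. Its nearest neighbour is compound 2 `Cc1ccc(NC(=O)CCc2cccc3c2B(O)OC3)cc1Br`, which in this assay gives 870 nM, a gap that lies within the usual scatter of such measurements, so the two cannot be told apart. Far away stands compound 3 `O=C(CCc1cccc2c1B(O)OC2)Nc1ccccc1-c1ccccc1`, which in this assay gives 18000 nM, a gap from compound 1 that is well beyond the scatter.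

The next compound, compound 4 `CSc1ccc(-c2cccc(NC(=O)CCc3cccc4c3B(O)OC4)c2)cc1`, differs from compound 1 in one place: 4-(methylsulfanyl)phenyl in place of isopropyl on an aromatic carbon The change replaces a small chain with a second aromatic ring that carries a methylsulfanyl group, set meta to a large group. Among the compounds with values here, no measured pair shows this kind of swap, so the size of the step is uncertain. Compound 3 shows that a large aromatic arm can be tolerated only poorly in one setting, yet compound 1 and compound 2 show that small groups on this ring give similar numbers. A modest step is expected, with the estimated shift from compound 1 to compound 4 being a 1.1-fold lower number from compound 1 to compound 4 (0.03 log units; within the scatter), possibly none beyond the scatter. Compound 4 is therefore expected to give about 1500 nM in this assay, with a likely range from 500 nM to 5000 nM.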

Compound 4, half-maximal inhibitory concentration: 140 nM
Compound 4: middle estimate off by 11-fold (1.03 log units), on the high side, and the stated range ends above it.
By their numbers in this assay, from the lowest: compound 4; then compounds 2 and 1 (each within the scatter of the next); then compound 3.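

In this assay, within the data shown here, putting 4-(methylsulfanyl)phenyl in place of isopropyl on this aromatic carbon gives an 11-fold lower number from compound 1 to compound 4 (1.06 log units; beyond the scatter) and provides the first direct reading of a change at this position. The position therefore accepts much more than a small chain: a group of 8 heavy atoms with its own six-membered aromatic ring replaces one of 3 heavy atoms, and the number falls well beyond the scatter rather than staying level or rising. Nothing measured here explains why the number falls so far.

The step changes two things at once, adding an aromatic ring and adding a methylsulfanyl group on that ring, so the compounds shown cannot say how much each contributes. A plain phenyl at this position would help to separate the two, and a methoxy group, an amine or a carboxylic acid in place of the methylsulfanyl group would show whether the sulfur-bearing group matters or whether the ring alone carries the change.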